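This account rests on a few compounds, and the source may have more. Where it says the series, first, only, none or still open, it means among the compounds named here.

Measured compounds in a functional assay on K562 cells (Homo sapiens) for antiproliferative activity, read by MTT assay, with a stated time of 24 h; a higher number here means a weaker inhibitor, a lower number a stronger inhibitor:
- compound 1 `COc1ccc(C(=O)/C=C/c2ccc(-c3ccccc3)cc2)c2c1C=CC(C)(C)O2` gives > 10000 nM in this assay; this is a limit of the assay and not a number.
- compound 2 `CCN(CC)c1ccc(/C=C/C(=O)c2ccc(OC)c3c2OC(C)(C)C=C3)cc1` gives 790 nM in this assay.
- compound 3 `COc1ccc(C(=O)/C=C/c2ccc(N3CCCC3)cc2)c2c1C=CC(C)(C)O2` gives 6180 nM in this assay.

Compound 3 thus carries the highest of the two numbers shown; its nearest neighbour is compound 2, and the step is a 7.8-fold higher number from compound 2 to compound 3 (0.89 log units; beyond the scatter). Compound 4 `COc1ccc(C(=O)/C=C/c2ccc([N+](=O)[O-])cc2)c2c1C=CC(C)(C)O2` differs from compound 3 in one place: nitro in place of pyrrolidin-1-yl on an aromatic carbon.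

Among the compounds with values here, three measured steps concern the same position on the shared core. Replacing phenyl by pyrrolidin-1-yl gave an at least 1.6-fold lower number from compound 1 to compound 3 (0.20 log units; that floor lies within the scatter), with compound 1 sitting at the limit (the limit of > 10000 nM in this assay, at which 1 of the 3 values shown sits). Replacing phenyl by diethylamino gave an at least 12-fold lower number from compound 1 to compound 2 (1.10 log units; beyond the scatter), and pyrrolidin-1-yl in place of diethylamino gave a 7.8-fold higher number from compound 2 to compound 3 (0.89 log units; beyond the scatter). Within the data shown here, none of these steps introduces a nitro group, so no measured step reaches the change in hand directly; the numbers show only that the group at this position can move the result widely. For compound 4 the expectation is therefore a step no larger than the scatter or a somewhat higher number, a 1.5-fold higher number from compound 3 to compound 4 (0.16 log units; within the scatter), with the possibility that only a limit is recorded. Compound 4 is estimated at 9000 nM, between 2500 nM and 30000 nM.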

Compound 4, half-maximal inhibitory concentration: 7770 nM
For compound 4 the middle estimate is 1.2-fold (0.06 log units) above the measured one, within the range that was stated.
By their numbers in this assay, from the lowest: compound 2; then compounds 3 and 4 (each within the scatter of the next). At a limit, above all of these: compound 1.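

Nitro, which has no ring, and pyrrolidin-1-yl, a five-membered non-aromatic ring, are not told apart at this place in this assay, where a 1.3-fold higher number from compound 3 to compound 4 (0.10 log units; within the scatter) is all that separates them. Diethylamino stands apart from nitro as well, with a 9.8-fold higher number from compound 2 to compound 4 (0.99 log units; beyond the scatter) showing that the earlier separation from pyrrolidin-1-yl is not particular to that ring. Against phenyl the step is an at least 1.2-fold lower number from compound 1 to compound 4 (0.10 log units; that floor lies within the scatter) and its starting point is a limit of the assay and not a number: the limit of > 10000 nM in this assay, at which 1 of the 4 values shown sits.

Going by these compounds, whether a dimethylamino group, a dipropylamino group or a primary amine at this place would fall with diethylamino or with pyrrolidin-1-yl and nitro stays open. A carboxylic acid here would test whether the low number depends on an amine at all, since nitro is the only non-amine beside phenyl.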